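Pyrazole Hydrazone Exchanged for Pyridine Hydrazone on a Triazine

The compounds below may be only part of what the source reports. "The series", "measured", "known", "first", "only" and "open" are said of these compounds alone.

Compound 2 `Cc1nn(-c2ccccc2)cc1/C=N/Nc1nc(Nc2ccccc2)nc(Nc2ccc(S(N)(=O)=O)cc2)n1` was tested in a functional assay on RPMI-8226 cells (Homo sapiens) for inhibition, read by sulforhodamine B assay, with a stated time of 48 h; a lower number here means that less compound is tolerated, a higher number that more compound is tolerated. In this assay compound 2 gives > 100000 nM, which is a limit of the assay and not a measured number. Within the data shown here, its one measured neighbour is compound 1 `NS(=O)(=O)c1ccc(Nc2nc(N/N=C/c3ccc(C(F)(F)F)cc3)nc(Nc3ccccc3)n2)cc1`, differing only in the group on the carbon carrying a double bond to nitrogen. In this assay compound 1 gives > 100000 nM, again a limit. The step that the two limits leave unreadable from compound 1 to compound 2 is therefore unreadable, as both values sit at the same limit (the limit of > 100000 nM in this assay, at which 2 of the 2 values shown sit). Compound 3 `NS(=O)(=O)c1ccc(Nc2nc(N/N=C/c3ccccn3)nc(Nc3ccccc3)n2)cc1` has not yet been measured. The change leading to it is pyridin-2-yl in place of 3-methyl-1-phenyl-1H-pyrazol-4-yl on a carbon with a double bond to nitrogen. That earlier step exchanged the group at the same place, but it tells nothing about direction or size. Nothing in the measured pair points towards potency appearing in this assay, and the most likely outcome is that compound 3 again reaches only the limit. Compound 3 is therefore expected to give about 100000 nM, with a range from 30000 nM to 300000 nM. The expected step of a number no higher from compound 2 to compound 3 (the limit leaves the size open) is thus none beyond the usual scatter.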

Compound 3, concentration lethal to 50% of the cells: > 100000 nM
Compound 3: no number, only a limit; the forecaster's own chance of this, stated with the estimate: 75%; the middle value sits exactly at the limit.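

In this assay compound 3 gives > 100000 nM as well, which is a limit and not a measured number. The steps among compound 1, compound 2 and compound 3 therefore cannot be read: the limit of > 100000 nM in this assay, at which 3 of the 3 values shown sit.

The compounds shown leave open whether any group on the carbon with a double bond to nitrogen can bring the result in this assay to a measurable number.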